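This account rests on a few compounds, and the source may have more. Where it says the series, first, only, none or still open, it means among the compounds named here.

Compound 1, `O=c1ncccn1SCCc1ccc(Nc2ncc(Cc3c(F)cccc3F)o2)cc1`, in an ADME assay on MT2 cells (Homo sapiens) for cytotoxicity, read by MTT assay (on this read-out higher numbers stand for lower toxicity in this test and lower numbers for higher toxicity in this test), gives a limit: > 100000 nM.
Compound 2, `N#Cc1ccc(Nc2ncc(Cc3c(F)cccc3F)o2)cc1`, gives 7400 nM.

Among the compounds with values here, compound 2 thus holds the only number in this assay; the other value is a limit (the limit of > 100000 nM in this assay, at which 1 of the 2 values shown sits). Compound 3, `Fc1cccc(F)c1Cc1cnc(Nc2ccc(Oc3cccnc3)cc2)o1`, differs from compound 2 by (pyridin-3-yl)oxy in place of cyano on an aromatic carbon. Within the data shown here, the single measured step bears on this: an at least 13-fold lower number from compound 1 to compound 2 (1.13 log units; beyond the scatter), the larger group sitting at the limit. The change toward compound 3 again enlarges the group at the same place, so a higher number is expected, a 6.8-fold higher number from compound 2 to compound 3 (0.83 log units; beyond the scatter). Compound 3 is estimated at 50000 nM, with a range from 12000 nM to 150000 nM, and a limit may well be reported instead.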

Compound 3, half-maximal cytotoxic concentration: 22000 nM
Estimate against measurement, compound 3: 2.3-fold (0.36 log units) above; measured number inside the range.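

At this aromatic carbon, a group carrying a ring gives a true number and not a limit in this assay, and replacing cyano with (pyridin-3-yl)oxy yields a 3.0-fold higher number from compound 2 to compound 3 (0.47 log units; beyond the scatter). Ring-bearing groups at this place therefore do not all behave alike, as the shorter (pyridin-3-yl)oxy group stays clearly apart from the larger group, with an at least 4.5-fold lower number from compound 1 to compound 3 (0.65 log units; beyond the scatter). Compound 1 remains a limit: the limit of > 100000 nM in this assay, at which 1 of the 3 values shown sits.

The compounds shown leave open whether an amine or a carboxylic acid at this place would fall within this range. They also leave open how a longer chain without a ring would compare.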